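The source may hold more compounds than are shown below. What is called first, only, known or untested is meant among the compounds shown, and "the series" means these compounds.

Measured compounds:
- compound 1 `C#Cc1cn([C@@H]2O[C@H](CO)[C@@H](O)[C@H]2O)c2ncnc(C)c12`: 19200 nM in a functional assay on A549 cells (Homo sapiens), read by MTT assay, with a stated time of 72 h; a lower number here means a stronger inhibitor, a higher number a weaker inhibitor
- compound 2 `C#Cc1cn([C@@H]2O[C@H](CO)[C@@H](O)[C@H]2O)c2ncnc(NC)c12`: > 20000 nM in this assay, a limit of the assay, not a number

Compound 2 therefore stands at the weak end of what this assay can report: in this assay compound 2 reaches only the limit, > 20000 nM. Going by the values given here, the single measured step, an at least 1.0-fold higher number from compound 1 to compound 2 (0.01 log units; that floor lies within the scatter), is itself a floor rather than a true size, because of the limit of > 20000 nM in this assay, at which 1 of the 2 values shown sits.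

Compound 3 `CNc1ncnc2c1c(-c1cc3ccccc3o1)cn2[C@@H]1O[C@H](CO)[C@@H](O)[C@H]1O` shares the methylamino-bearing core of compound 2 and differs in one place: 1-benzofuran-2-yl in place of ethynyl on an aromatic carbon. Among the compounds with values here, no measured step covers a change of this kind; the one step on record swaps a small group on a different aromatic carbon and sits within the scatter, so it gives no guide to the effect of a bulky fused aromatic group entering here. The expectation must therefore rest on the size of the change alone, and it is held loosely. The step of an at least 10-fold lower number from compound 2 to compound 3 (1.00 log units; beyond the scatter) is the estimated outcome. Compound 3 is expected to give about 2000 nM in this assay, within a wide range from 100 nM to 20000 nM.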

Compound 3, half-maximal inhibitory concentration: > 20000 nM
Compound 3 was reported as a limit; the forecaster's own chance of this, stated with the estimate: 25%; middle value at least 10-fold (1.00 log units) from the limit.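

In this assay compound 3 gives > 20000 nM and this is a limit of the assay, not a number. Going by these compounds alone, no step from compound 2 to compound 3 can be read, because both compounds sit at the same limit: the limit of > 20000 nM in this assay, at which 2 of the 3 values shown sit. The compounds shown leave open whether 1-benzofuran-2-yl in place of ethynyl changes inhibition at all, and in which direction.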